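This account rests on a few compounds, and the source may have more. Where it says the series, first, only, none or still open, it means among the compounds named here.

Measured so far:
compound 1, `Nc1cc(C(=O)O)ccc1CN1CCC[C@H](O[C@H](CO)c2cc(Cl)cc(Cl)c2)[C@@H]1c1ccccc1` — 290 nM
compound 2, `COC(=O)Nc1cc(C(=O)O)ccc1CN1CCC[C@H](O[C@H](CO)c2cc(Cl)cc(Cl)c2)[C@@H]1c1ccccc1` — 1000 nM
compound 3, `O=C(O)c1ccc(CN2CCC[C@H](O[C@H](CO)c3cc(Cl)cc(Cl)c3)[C@@H]2c2ccccc2)c(C2CC2)c1` — 1800 nM

In an assay on isolated protein for activation of cGMP-dependent protein kinase 1 (Homo sapiens), read by ADP-Glo, with stated times of 30 min and 2 h, in the presence of a further agent that is not named here (on this read-out lower numbers stand for an effect already at smaller amounts and higher numbers for an effect only at larger amounts of compound), compound 1 stands lowest of the three numbers, with compound 2 nearest at a 3.4-fold higher number from compound 1 to compound 2 (0.54 log units; beyond the scatter) and compound 3 furthest at a 6.2-fold higher number from compound 1 to compound 3 (0.79 log units; beyond the scatter). Both of those steps alter the amino group on the aromatic ring of the benzyl arm, and both are modest rises beyond the scatter; compound 2 and compound 3 themselves differ by a 1.8-fold higher number from compound 2 to compound 3 (0.26 log units; within the scatter).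

Compound 4, `Cc1cc(C(=O)O)ccc1C(=O)N1CCC[C@H](O[C@H](CO)c2cc(Cl)cc(Cl)c2)[C@@H]1c1ccccc1`, is not yet measured. It differs from compound 1 as follows: a group of 12 heavy atoms (9 carbon, 3 oxygen; one six-membered aromatic ring of carbon only) in place of a group of 11 heavy atoms (8 carbon, 1 nitrogen, 2 oxygen; one six-membered aromatic ring of carbon only), on an amine nitrogen in a ring. The group that enters carries a methyl where compound 1 carries amino, and it joins the ring nitrogen through a carbonyl rather than directly through a saturated carbon, so the ring nitrogen is no longer an amine. The measured steps bear on only the first part of this change: each replacement of the amino group so far gave a higher number. Among the measured compounds shown here, the altered linkage has no measured counterpart. The expectation for compound 4 in this assay is therefore a higher number, likely larger than the steps seen, a 10-fold higher number from compound 1 to compound 4 (1.01 log units; beyond the scatter), with wide uncertainty. Compound 4 is estimated at 3000 nM, within a range from 700 nM to 13000 nM.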

Compound 4, half-maximal effective concentration: > 200000 nM
Compound 4 was reported as a limit; the forecaster's own chance of this, stated with the estimate: 15%; middle value at least 66-fold (1.82 log units) from the limit.
By their numbers in this assay, from the lowest: compound 1; then compounds 2 and 3 (each within the scatter of the next). At a limit, above all of these: compound 4.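

The value for compound 4 is a limit of the assay and not a number: the limit of > 200000 nM in this assay, at which 1 of the 4 values shown sits. In this assay, the earlier replacements changed only the amino group and gave modest steps, such as a 6.2-fold higher number from compound 1 to compound 3 (0.79 log units; beyond the scatter), whereas the change in compound 4, which also joins the benzene ring to the ring nitrogen through a carbonyl, gives an at least 680-fold higher number from compound 1 to compound 4 (2.83 log units; beyond the scatter). So the group on this ring nitrogen tolerates replacement of its amino group far better than this combined change, which is a large step rather than a modest one.

Compound 4 changes two things at once, the methyl in place of amino and the carbonyl in place of the saturated carbon, and the compounds shown cannot say how much of the step belongs to each. Open too, going by these compounds, are a methyl group on the saturated carbon link, an amino group on the carbonyl link, and other links to the ring nitrogen, such as a sulfonyl group or a longer chain of two saturated carbons.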